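The source may report more compounds than this note shows. Statements on the series, on what has been measured and on what is new or still open speak of the compounds shown alone.

Measured compounds: compound 1 `CCCc1nn(-c2nc(N)c3c(n2)NC(=O)C3(C)C)c2ccc(Cl)cc12` gives 546000 nM in an assay on CHO cells for activation of soluble guanylate cyclase alpha1/beta1 complex (Homo sapiens), read by cGMP accumulation; on this read-out higher numbers stand for an effect only at larger amounts of compound and lower numbers for an effect already at smaller amounts; compound 2 `CC1(C)C(=O)Nc2nc(-n3nc(CCCC(F)(F)F)c4cc(Cl)ccc43)nc(N)c21` gives 117000 nM; compound 3 `COC(=O)N(C)c1c(N)nc(-c2nc(Cc3ccccc3F)n3ccccc23)nc1N` gives 20400 nM.

Compound 2 stands second highest of the three numbers, with compound 1 higher and compound 3 lower by steps beyond the scatter. Compound 4 `CCCCc1nn(-c2nc(N)c3c(n2)NC(=O)C3(C)C)c2ccc(Cl)cc12` is not yet measured; it differs from compound 2 by methyl in place of trifluoromethyl on a saturated chain carbon, three bonds along the chain from an aromatic carbon. Among the measured compounds shown here, the only measured step that bears on this is a 4.7-fold lower number from compound 1 to compound 2 (0.67 log units; beyond the scatter), which placed the trifluoromethyl. For the measured compounds named here, compound 4 removes it again but keeps a longer chain than compound 1, and no step on chain length alone exists here. The expectation is therefore a rise toward compound 1, estimated as a 3.0-fold higher number from compound 2 to compound 4 (0.48 log units; beyond the scatter), and compound 4 is expected near 350000 nM with a range of 100000 nM to 1000000 nM.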

Compound 4, half-maximal effective concentration: 47000 nM
The estimate for compound 4 lay 7.4-fold (0.87 log units) above the measured number; the measured number lies below the stated range.
By their numbers in this assay, from the lowest: compound 3; then compound 4; then compound 2; then compound 1.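

On the saturated chain carbon, three bonds along the chain from an aromatic carbon, methyl in place of hydrogen gives a 12-fold lower number from compound 1 to compound 4 (1.07 log units; beyond the scatter) in this assay and so outdoes the earlier trifluoromethyl change at this place. Methyl in place of trifluoromethyl gives a 2.5-fold lower number from compound 2 to compound 4 (0.40 log units; beyond the scatter) here, so the fluorines are not needed for the lower number and the plain butyl chain does better than 4,4,4-trifluorobutyl. Nothing available explains this difference.

Open, as far as these compounds go, is whether a longer chain such as pentyl lowers the number further or reverses the trend. Also open, from the compounds shown here alone, is how a terminal amine or carboxylic acid on the chain would read.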